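A few compounds are considered here, and "the series" means these few. Any claim that something is new, unique, unknown or untested is made for them only; others in the source may bear on it.

Compound 2 `COc1ccc(C2OC(c3cc(OC)c(OC)c(OC)c3)=NN2C(C)=O)c(OC)c1` stands highest of the three compounds measured in a functional assay on PC-3 cells (Homo sapiens) for antiproliferative activity, read by MTT assay, tested at 5 uM (a higher number here means a stronger effect of the compound at the concentration tested, a lower number a weaker effect), with 92%. Compound 1 `COc1ccc(OC)c(/C=N/NC(=O)c2cc(OC)c(OC)c(OC)c2)c1` gives 51.7%, and compound 3 `COc1cc(C(=O)N/N=C/c2ccc(F)c(F)c2)cc(OC)c1OC` gives 43.7%; both lie below compound 2 by more than the usual scatter. Compound 4 `COc1cc(C2=NN(C(C)=O)C(c3ccc(F)cc3)O2)cc(OC)c1OC` has not yet been measured. It differs from compound 2 in one place: 4-fluorophenyl in place of 2,4-dimethoxyphenyl on a saturated ring carbon. Among the compounds with values here, no pair among the measured compounds isolates this change, so its effect rests on judgement alone. A moderate loss is expected, a number 17 percentage points lower from compound 2 to compound 4 (beyond the scatter), since the shared core of compound 2 is kept and only the aryl group on the saturated ring carbon is exchanged. Compound 4 is therefore estimated at 75%, within 55% to 93%.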

Compound 4, a percentage reported as inhibition, at one concentration (the size of the read-out at that concentration, not a potency): 0.1%
Beside the measured number, compound 4's estimate is 74.9 percentage points above it; the measured number lies below the stated range.
By their numbers in this assay, from the lowest: compound 4; then compounds 3 and 1 (each within the scatter of the next); then compound 2.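

In this assay the aryl group on the saturated ring carbon proves decisive: 4-fluorophenyl in place of 2,4-dimethoxyphenyl gives a number 91.9 percentage points lower from compound 2 to compound 4 (beyond the scatter) and leaves almost none of the effect of compound 2 at the concentration tested. The earlier compounds shown here held no pair differing in one place, so they could not show this. Nothing measured here accounts for the loss. On these data alone, whether it follows from losing the methoxy groups or from gaining the fluorine remains open. A 4-methoxyphenyl or 4-aminophenyl group on the same carbon would help separate the two.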